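Amine changes on the shared core: notes toward compound 4

This account rests on a few compounds, and the source may have more. Where it says the series, first, only, none or still open, it means among the compounds named here.

Compound 1 `CCCN(CCC)Cc1ccc(Cl)c(-c2ccccc2OC)c1`; in an assay on isolated protein for binding affinity to 5-hydroxytryptamine receptor 1D (Homo sapiens) (on this read-out higher numbers stand for weaker inhibition and lower numbers for stronger inhibition), compound 1 gives only a limit, > 10000 nM.
Compound 2 `COc1ccccc1-c1cc(C2CCNC2)ccc1Cl`; in this assay compound 2 gives 3.4 nM.
Compound 3 `COc1ccccc1-c1cc(CN(C)C)ccc1Cl`; in this assay compound 3 gives 1300 nM.

Compound 3 stands highest of the two numbers, set by a 380-fold higher number from compound 2 to compound 3 (2.58 log units; beyond the scatter). Compound 1 sits at the limit (the limit of > 10000 nM in this assay, at which 1 of the 3 values shown sits).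

Compound 4 `CCCNCc1ccc(Cl)c(-c2ccccc2OC)c1` differs from compound 3 by propylamino in place of dimethylamino on a saturated chain carbon bound to an aromatic carbon. Within the data shown here, two steps bear on it: an at least 7.6-fold lower number from compound 1 to compound 3 (0.88 log units; beyond the scatter), where trimming two propyl chains to methyls helped, and a 380-fold higher number from compound 2 to compound 3 (2.58 log units; beyond the scatter), where the group with a hydrogen-bond donor was far stronger. Compound 4 keeps one propyl but gains a donor; a modest lowering is expected, a 3.3-fold lower number from compound 3 to compound 4 (0.51 log units; beyond the scatter). Compound 4 is estimated at 400 nM, between 60 nM and 2500 nM.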

Compound 4, inhibition constant: 220 nM
Estimate against measurement, compound 4: 1.8-fold (0.26 log units) above; low and high end bracket the measured number.
By their numbers in this assay, from the lowest: compound 2; then compound 4; then compound 3. At a limit, above all of these: compound 1.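

Propylamino in place of dimethylamino on a saturated chain carbon bound to an aromatic carbon gives, in this assay, a 5.9-fold lower number from compound 3 to compound 4 (0.77 log units; beyond the scatter), so a propyl chain on this amine is compatible with a lower number. For compound 1 the value is a limit, so hydrogen in place of propyl on an amine nitrogen reads only as an at least 45-fold lower number from compound 1 to compound 4 (1.65 log units; beyond the scatter): the limit of > 10000 nM in this assay, at which 1 of the 4 values shown sits.
The pyrrolidin-3-yl group keeps a clear lead, with (propylamino)methyl in its place giving a 65-fold higher number from compound 2 to compound 4 (1.81 log units; beyond the scatter).

Open, going by these compounds, is how methylamino, ethylamino or butylamino would compare on the same carbon. Compound 4 alone cannot separate the gain of the amine hydrogen from the change in chain length.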